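The source may hold more compounds than are shown below. What is called first, only, known or untested is meant among the compounds shown, and "the series" means these compounds.

Compound 1 `COc1ccc(C(=O)NC[C@H]2c3[nH]c4ccccc4c3C[C@H]3[C@H]4c5[nH]c6ccccc6c5C[C@@H]([C@H](C#N)N23)N4C)cc1`: 430 nM in a functional assay on HCT-116 cells (Homo sapiens) for cytotoxicity, read by MTT assay, with a stated time of 72 h; on this read-out higher numbers stand for weaker inhibition and lower numbers for stronger inhibition; compound 2 `CN1[C@@H]2c3[nH]c4ccccc4c3C[C@H]1[C@H](C#N)N1[C@@H](CNC(=O)c3ccc4ccccc4c3)c3[nH]c4ccccc4c3C[C@@H]21`: 420 nM in this assay.

Compound 1 has the highest of the two numbers, with compound 2 nearest, and the step of a 1.0-fold lower number from compound 1 to compound 2 (0.01 log units; within the scatter) lies within the scatter. Compound 3 `CN1[C@@H]2c3[nH]c4ccccc4c3C[C@H]1[C@H](C#N)N1[C@@H](CNC(=O)/C=C/c3ccccc3)c3[nH]c4ccccc4c3C[C@@H]21` has not yet been measured. It differs from compound 1 by 2-phenylethenyl in place of 4-methoxyphenyl on a carbonyl carbon. Going by the values given here, only the step from compound 1 to compound 2 bears on this change, since it also exchanges the group on that carbonyl carbon, and it stayed within the scatter. Compound 3 is therefore expected to show no step beyond the scatter, a 1.0-fold higher number from compound 1 to compound 3 (0.02 log units; within the scatter). Compound 3 is estimated in this assay at 450 nM, within a range from 200 nM to 1000 nM.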

Compound 3, half-maximal inhibitory concentration: 1960 nM
Compound 3: the middle estimate sits 4.4-fold (0.64 log units) below what was measured; measured number above the stated range.
By their numbers in this assay, from the lowest: compounds 2 and 1 (each within the scatter of the next); then compound 3.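

In this assay, 2-phenylethenyl on this carbonyl carbon gives a 4.6-fold higher number from compound 1 to compound 3 (0.66 log units; beyond the scatter) and also a 4.7-fold higher number from compound 2 to compound 3 (0.67 log units; beyond the scatter). So this position does not treat all groups alike, even though 4-methoxyphenyl and naphthalen-2-yl could not be told apart. Nothing measured here explains why the 2-phenylethenyl group differs. As far as these compounds go, it remains open whether the double bond outside the aromatic ring matters, and a 2-phenylethyl group, the same chain without that double bond, would test this. How an amine on the aromatic ring would fare at this position is also unknown.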